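The source may hold more compounds than are shown below. What is called first, only, known or untested is meant among the compounds shown, and "the series" means these compounds.

Compound 1 `COCOc1cc(/C=C/C(=O)OCC(=O)Nc2ccc(Cl)cc2)ccc1OCc1ccccc1`: > 200000 nM
Compound 2 `CCOc1ccc(COc2c(OC)cc(/C=C/C(=O)OCC(=O)Nc3ccccc3)cc2OC)cc1`: > 200000 nM
Compound 3 `COc1cc(/C=C/C(=O)OCC(=O)Nc2ccc(Cl)cc2)cc(OC)c1OCc1ccc(Cl)c(Cl)c1`: > 200000 nM

These three compounds share a core and were tested in a functional assay on K562 cells (Homo sapiens) for cytotoxicity, read by MTT assay, with a stated time of 72 h; a lower number here means a stronger inhibitor, a higher number a weaker inhibitor. In this assay compound 1 gives > 200000 nM, which is a limit of the assay and not a measured number. Compound 2 likewise gives only a limit, > 200000 nM. Compound 3 also gives a limit, > 200000 nM. So compound 1 stands where every compound here stands: at the limit of > 200000 nM in this assay, at which 3 of the 3 values shown sit. Among the compounds with values here, no two of the measured compounds differ in a single place, so there is no measured step that shows how one change moves the number; all that can be said is that none of the three reaches a measurable value.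

Compound 4 `COCOc1cc(/C=C/C(=O)OCC(=O)Nc2nccs2)ccc1OCc1ccccc1` is the next compound, not yet measured. It differs from compound 1 by 1,3-thiazol-2-yl in place of 4-chlorophenyl on an amide-type nitrogen. Within the data shown here, with every measured value sitting at a limit, there is no step to compare this change against, and the expected step from compound 1 to compound 4, a step that the limit leaves unreadable from compound 1 to compound 4, is one of no clear direction. For compound 4 the estimate in this assay is 250000 nM. Its range is expected to run from 60000 nM to 1000000 nM, with a limit the most likely outcome.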

Compound 4, half-maximal inhibitory concentration: > 200000 nM
Compound 4 ended at the assay's limit; the forecaster's own chance of this, stated with the estimate: 75%; the middle value is on the limit's open side.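

Compound 1 and compound 4 both end at a limit in this assay rather than at a number, so swapping 4-chlorophenyl for 1,3-thiazol-2-yl gives no step that can be read: the limit of > 200000 nM in this assay, at which 4 of the 4 values shown sit.

The compounds shown leave open whether any change to the shared core would give a real number in this assay.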